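Removing the halogen from compound 2

This account rests on a few compounds, and the source may have more. Where it says the series, first, only, none or still open, it means among the compounds named here.

Measured in an ADME assay on HepG2 cells (Homo sapiens) for cytotoxicity, read by CellTiter-Glo, with a stated time of 48 h; a higher number here means that more compound is tolerated, a lower number that less compound is tolerated:
compound 1 `CS(=O)(=O)c1ccc(-c2nc3ccc(Cl)cc3nc2-c2ccc(Cl)cc2)cc1` - 2000 nM
compound 2 `CS(=O)(=O)c1ccc(-c2nc3ccc(Br)cc3nc2-c2ccc(Cl)cc2)cc1` - 2000 nM
compound 3 `COc1ccc2nc(-c3ccc(-c4ccccc4)cc3)c(-c3ccc(S(C)(=O)=O)cc3)nc2c1` - > 100000 nM

Compound 2 reads 2000 nM, level with compound 1, which is its nearest neighbour in the series. The entry for compound 3 is a limit of the assay and not a number. Among the measured compounds shown here, no single-place step joins compound 3 to the other two, so it gives no direct size for the change at hand.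

The next compound to read is compound 4 `CS(=O)(=O)c1ccc(-c2nc3ccccc3nc2-c2ccc(Cl)cc2)cc1`. The change is hydrogen in place of bromo on an aromatic carbon. For the measured compounds named here, the only measured step that bears on it is the exchange of one halogen for another, no change at the digits printed from compound 1 to compound 2 (within the scatter). Going by the values given here, that step does not show what happens when no halogen is present, and no measured pair covers this removal. A small step is therefore expected in this assay, little beyond the scatter and, if anything, towards more compound tolerated. The upper end of the range is kept wide because of > 100000 nM, the limit reached by compound 3. The expected step is a 2.0-fold higher number from compound 2 to compound 4 (0.30 log units; within the scatter). For compound 4 the estimate is 4000 nM, with an expected range of 1500 nM to 15000 nM.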

Compound 4, half-maximal cytotoxic concentration: 10000 nM
Compound 4: middle estimate off by 2.5-fold (0.40 log units), on the low side; low and high end bracket the measured number.
By their numbers in this assay, from the lowest: compounds 1 and 2 (each within the scatter of the next); then compound 4. At a limit, above all of these: compound 3.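

In this assay, this position on the aromatic carbon responds once the halogen is gone: hydrogen in place of bromo gives a 5.0-fold higher number from compound 2 to compound 4 (0.70 log units; beyond the scatter), and hydrogen in place of chloro gives a 5.0-fold higher number from compound 1 to compound 4 (0.70 log units; beyond the scatter). The earlier exchange of one halogen for the other gave no change at the digits printed from compound 1 to compound 2 (within the scatter), so it could not show that this place affects the read-out at all; among these three compounds, the difference lies between carrying either halogen and carrying hydrogen, not between chloro and bromo. No measurement shown here bears on the cause of this step.

Among the compounds shown here, compound 3 reads > 100000 nM, which is a limit of the assay and not a number, and no single-place step joins it to compound 4, so it adds nothing about this position. From the compounds shown here alone, it remains open whether fluoro, an amine or a carboxylic acid on this aromatic carbon would read with the two halogens, with hydrogen or apart from both, and whether the step from removing the halogen holds when the chloro on the other aromatic ring is changed.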